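The source may report more compounds than this note shows. Statements on the series, on what has been measured and on what is new or still open speak of the compounds shown alone.

Series notes, agonist activity at the target receptor. Three compounds on the shared core carry the ring substituent in different forms: compound 1 `CC(C)Oc1ccccc1OC(C)C1=NCCN1`, compound 2 `C=COc1ccccc1OC(C)C1=NCCN1` and compound 3 `CC(Oc1ccccc1S(C)(=O)=O)C1=NCCN1`. In a functional assay on CHO cells for agonist activity at Alpha-2B adrenergic receptor (Homo sapiens) (a lower number here means that less compound is needed, a higher number that more compound is needed for the effect), compound 1 gives 1740 nM, compound 2 gives 3160 nM and compound 3 gives 10000 nM. Among the three, compound 3 stands at the highest number: the step of a 5.7-fold higher number from compound 1 to compound 3 (0.76 log units; beyond the scatter) and the step of a 3.2-fold higher number from compound 2 to compound 3 (0.50 log units; beyond the scatter) both go up beyond the scatter, while the step of a 1.8-fold higher number from compound 1 to compound 2 (0.26 log units; within the scatter) stays within it.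

The next compound, compound 4 `CC(=O)c1ccccc1OC(C)C1=NCCN1`, differs from compound 3 in one place: acetyl in place of methylsulfonyl on an aromatic carbon. The methylsulfonyl group is thus removed and an acetyl group takes its place on the same aromatic carbon, ortho to the group of 8 heavy atoms.

The two steps that bear on this change are those that put the methylsulfonyl group in, from compound 1 and from compound 2, each raising the number modestly in this assay. Taking the methylsulfonyl group out again, in favour of a smaller group with one acceptor, is therefore expected to lower the number somewhat, though the acetyl group has no direct precedent in the series. The estimated step from compound 3 to compound 4 is a 2.0-fold lower number from compound 3 to compound 4 (0.30 log units; within the scatter). Compound 4 is expected to give about 5000 nM in this assay, within a range from 1500 nM to 20000 nM.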

Compound 4, half-maximal effective concentration: 295 nM
Compound 4: middle estimate off by 17-fold (1.23 log units), on the high side; measured number outside the range, below it.
By their numbers in this assay, from the lowest: compound 4; then compounds 1 and 2 (each within the scatter of the next); then compound 3.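

Acetyl is the only group in the series that brings the number in this assay below the others at this aromatic carbon, with a 5.9-fold lower number from compound 1 to compound 4 (0.77 log units; beyond the scatter) and an 11-fold lower number from compound 2 to compound 4 (1.03 log units; beyond the scatter) as well as a 34-fold lower number from compound 3 to compound 4 (1.53 log units; beyond the scatter) as the largest step among the four compounds. The earlier compounds shown here showed only that methylsulfonyl stands higher than the two alkoxy-type groups; the new steps show that this position can also move the number well down, and that the choice between two non-ring groups with no hydrogen-bond donors, differing by one heavy atom and one hydrogen-bond acceptor by count, can decide much of the range seen so far. Nothing at hand bears on the reason for the gap between acetyl and methylsulfonyl.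

The compounds shown cannot tell whether the lower number follows the carbonyl itself or the acetyl group as a whole. As far as these compounds go, how a methyl ester, a primary amide or a nitrile on this aromatic carbon would compare with acetyl remains open, as does whether a longer ketone such as propanoyl would hold the number of compound 4.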